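The source may hold more compounds than are shown below. What is called first, only, known or untested is meant among the compounds shown, and "the series" means these compounds.

Measured compounds:
compound 1 `CCCN(CCC)S(=O)(=O)c1ccc(S(=O)(=O)N2CCC[C@@H](C(=O)OCC)C2)cc1` gives 2300 nM
compound 2 `CCN(CC)S(=O)(=O)c1ccc(S(=O)(=O)N2CCC[C@@H](C(=O)NC3CN(S(C)(=O)=O)C3)C2)cc1` gives 2500 nM

In a functional assay on MIA PaCa-2 cells (Homo sapiens) for inhibition, read by MTT assay, with a stated time of 7 days (a lower number here means a stronger inhibitor, a higher number a weaker inhibitor), compound 1 gives 2300 nM, the lowest of the two numbers recorded so far. Compound 2 gives 2500 nM, and the gap to compound 1 lies within the scatter, so no order between the two can be read from these values; they show only that both sit in the same region.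

Compound 3 `CCCN(CC)S(=O)(=O)c1ccc(S(=O)(=O)N2CCC[C@@H](C(=O)OCC)C2)cc1` has not yet been measured. It differs from compound 1 in one place: hydrogen in place of methyl on a saturated chain carbon, two bonds along the chain from a sulfonamide nitrogen. Within the data shown here, no step between measured compounds is available that would show what such a change does on this core. The change is small, removing one carbon from a chain on the sulfonamide nitrogen and leaving the rest of compound 1 untouched. The step of a 1.1-fold higher number from compound 1 to compound 3 (0.04 log units; within the scatter) is therefore expected to stay within the scatter, with no direction favoured. Compound 3 is estimated to give 2500 nM in this assay, with a range from 1200 nM to 5500 nM.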

Compound 3, half-maximal inhibitory concentration: 300 nM
Estimate against measurement, compound 3: 8.3-fold (0.92 log units) above; measured number outside the range, below it.
By their numbers in this assay, from the lowest: compound 3; then compounds 1 and 2 (each within the scatter of the next).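

In this assay, the change from dipropylamino to ethyl(propyl)amino gives a 7.7-fold lower number from compound 1 to compound 3 (0.88 log units; beyond the scatter), so the loss of a single methyl on a saturated chain carbon, two bonds along the chain from a sulfonamide nitrogen, moves the number beyond the scatter on the core of compound 1. The earlier pair could not show this sensitivity: compound 1 and compound 2 differ in more than one place, so no single change can be read from them. Nothing at hand accounts for the size of this step or says why the shorter chain gives the lower number.

Still open, going by these compounds, is whether the trend depends on the total chain length on the sulfonamide nitrogen or on the two chains being unequal, which a methyl(propyl)amino or a butyl(ethyl)amino group on the core of compound 3 would help to separate. Among these compounds, also open is whether the same change carries over to other cores, since the single step here rests on one pair of compounds in one assay.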